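Dropping one methoxy from compound 1

A few compounds are considered here, and "the series" means these few. Any claim that something is new, unique, unknown or untested is made for them only; others in the source may bear on it.

Of the compounds shown here, two have been measured in a functional assay on 3T3-L1 cells (Mus musculus) for inhibition, with a stated time of 20 min, tested at 20 uM; on this read-out higher numbers stand for more inhibition at the one concentration tested (going by the name of the read-out) and lower numbers for less inhibition. Compound 1 `COc1ccc(Cn2cc(CN(Cc3cn(S(=O)(=O)c4ccc(C)cc4)c4ccccc34)S(=O)(=O)c3ccc(C)cc3)nn2)c(OC)c1` gives 7.6% in this assay. Compound 2 `Cc1ccc(S(=O)(=O)N(Cc2cn(Cc3cc(F)ccc3F)nn2)Cc2cn(S(C)(=O)=O)c3ccccc23)cc1` gives 3.4% in this assay. The two numbers lie within the usual scatter of each other, so compound 1 cannot be set apart from compound 2; both numbers are low. Among the measured compounds shown here, compound 2 differs from compound 1 in several places at once, so no single step is recorded between them.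

Compound 3 `COc1ccc(Cn2cc(CN(Cc3cn(S(=O)(=O)c4ccc(C)cc4)c4ccccc34)S(=O)(=O)c3ccc(C)cc3)nn2)cc1` has not been measured. It differs from compound 1 in one place: hydrogen in place of methoxy on an aromatic carbon. Cut one bond further out, the 2,4-dimethoxybenzyl of compound 1 becomes a 4-methoxybenzyl in compound 3.

For the measured compounds named here, no measured pair shows what this change does here. Given that compound 1 gives 7.6% and compound 2 gives 3.4%, both small, nothing in the data suggests a move beyond the scatter; the expected step from compound 1 to compound 3 is a number 1.6 percentage points lower from compound 1 to compound 3 (within the scatter), with no clear direction. Compound 3 is expected to give 6% in this assay, within a range of -4% to 16%.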

Compound 3, a percentage reported as inhibition, at one concentration (the size of the read-out at that concentration, not a potency): 1%
For compound 3 the middle estimate is 5 percentage points above the measured one; low and high end bracket the measured number.
By their numbers in this assay, from the lowest: compounds 3, 2 and 1 (each within the scatter of the next).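

Among the compounds shown here, this is the first one-place step: in this assay, hydrogen in place of methoxy on the aromatic carbon ortho to a large group gives a number 6.6 percentage points lower from compound 1 to compound 3 (within the scatter). The 2,4-dimethoxybenzyl of compound 1 and the 4-methoxybenzyl of compound 3 therefore cannot be set apart on this read-out, and the methoxy at this position shows no effect that can be distinguished from the usual scatter, although this rests on a single pair with low numbers at one concentration. No supporting measurement bears on this step, so the data offer no account of what the methoxy does or does not do at this position.

From the compounds shown here alone, it remains open whether any group at this aromatic carbon can move the number beyond the scatter, for example an amine or a carboxylic acid in place of the methoxy of compound 1. Also open, going by these compounds, is whether the remaining methoxy matters, which a hydroxyl or a longer alkoxy chain in its place on compound 3 would test.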